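Benzoyloxy in place of 2,5-dioxopyrrolidin-1-yl

The compounds below may be only part of what the source reports. "The series", "measured", "known", "first", "only" and "open" are said of these compounds alone.

In a physicochemical assay for solubility, read by HPLC, with a stated time of 24 h (on this read-out higher numbers stand for higher solubility and lower numbers for lower solubility), compound 1 (`O=C1O[C@@H](CO)CN1c1ccc(-n2cc(-c3ccccn3)cn2)c(F)c1`) gives 56400 nM and compound 2 (`O=C1CCC(=O)N1C[C@H]1CN(c2ccc(-n3cc(-c4ccccn4)cn3)c(F)c2)C(=O)O1`) gives 45300 nM within the scatter of it. Compound 3 (`O=C(OC[C@H]1CN(c2ccc(-n3cc(-c4ccccn4)cn3)c(F)c2)C(=O)O1)c1ccccc1`) carries benzoyloxy in place of 2,5-dioxopyrrolidin-1-yl on a saturated chain carbon bound to a saturated ring carbon. Going by the values given here, the only measured step at this place (a 1.2-fold lower number from compound 1 to compound 2 (0.10 log units; within the scatter)) stayed within the scatter, but no six-membered aromatic ring of carbon only entered there. That leaves a thin basis, and a modest step to a lower number is expected (a 2.5-fold lower number from compound 2 to compound 3 (0.40 log units; beyond the scatter)) with wide margins. Compound 3 is estimated at 18000 nM (expected range 4000 nM to 50000 nM).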

Compound 3, solubility: <= 65400 nM
Compound 3: a limit, no number; the forecaster's own chance of this, stated with the estimate: 10%; the middle value lies beyond the limit too.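

In this assay compound 3 gives <= 65400 nM, which is a limit and not a number. The steps from compound 1 and compound 2 to compound 3 therefore cannot be read. As far as these compounds go, whether benzoyloxy gives a higher or lower number than hydroxy or 2,5-dioxopyrrolidin-1-yl at this place stays open.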